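The compounds below may be only part of what the source reports. "The series", "measured", "known", "first", "only" and "open" are said of these compounds alone.

Measured so far:
compound 1, `COc1cc(Cl)cc(-c2nn(-c3cccc(NC(=O)Nc4ccc(Cl)c(C(F)(F)F)c4)c3)cc2-c2ccncc2)c1`: -6%
compound 2, `COc1cc(Cl)cc(-c2nn(-c3cccc(NC(=O)Nc4cc(C(F)(F)F)cc(C(F)(F)F)c4)c3)cc2-c2ccncc2)c1`: -25%

In a functional assay on Hs-578T cells (Homo sapiens) for inhibition, read by sulforhodamine B assay, with a stated time of 48 h, tested at 100 uM (on this read-out lower numbers stand for a stronger effect and higher numbers for a weaker effect at the one concentration tested), compound 1 gives -6%, the highest of the two numbers measured. Within the data shown here, compound 2 gives -25%, a number that lies below the one for compound 1 by more than the usual scatter, so of these two, compound 2 shows the stronger effect at the single concentration tested.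

Compound 3, `COc1cc(Cl)cc(-c2nn(-c3cccc(NC(=O)Nc4cccc(C(F)(F)F)c4)c3)cc2-c2ccncc2)c1`, is the next point. Against compound 1 the change is hydrogen in place of chloro on an aromatic carbon. Among the measured compounds shown here, no measured pair carries this change, so there is no direct guide to its size; the two measured compounds differ elsewhere on the same ring and do not speak to it. The expected step of a number 4 percentage points higher from compound 1 to compound 3 (within the scatter) is estimated to stay within the scatter, with a slight lean upward. Compound 3 is expected to give -2%, in a range from -22% to 16%.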

Compound 3, a percentage reported as activity, at one concentration (the size of the read-out at that concentration, not a potency): 21%
Estimate against measurement, compound 3: 23 percentage points below, and the stated range ends below it.
By their numbers in this assay, from the lowest: compound 2; then compound 1; then compound 3.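

In this assay, hydrogen in place of chloro on this aromatic carbon gives a number 27 percentage points higher from compound 1 to compound 3 (beyond the scatter), so the effect at the one concentration tested depends on what this position carries. Hydrogen in place of trifluoromethyl gives the larger a number 46 percentage points higher from compound 2 to compound 3 (beyond the scatter), and among these three compounds, the two with a second substituent on this ring show the stronger effect. No data at hand explain either step.

Compounds 1 and 2 differ in both the group and its place on the ring, so these two factors remain unseparated. From the compounds shown here alone, how a methoxy group, a nitrile or an amine would read at the position of the chloro also remains open, as does whether any such group would restore the effect seen with compound 1.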